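The source may hold more compounds than are shown below. What is called first, only, known or untested is meant among the compounds shown, and "the series" means these compounds.

In a functional assay on PLC5 cells (Homo sapiens) for inhibition, read by MTT assay, with a stated time of 24 h (on this read-out higher numbers stand for weaker inhibition and lower numbers for stronger inhibition), compound 1 `COc1ccc(CNC(=O)NCc2ccc(Oc3ccc(C#N)cc3)cc2)cc1OC` gives 10500 nM. Compound 2 `N#Cc1ccc(Oc2cccc(NCc3cccc(OC(F)(F)F)c3)c2)cc1` reaches only a limit of this assay, > 15000 nM, so its true value is not known; that limit is the one noted as the limit of > 15000 nM in this assay, at which 1 of the 2 values shown sits. Compound 3 `CNC(=O)c1cc(Oc2cccc(NCc3cccc(OC(F)(F)F)c3)c2)ccn1` differs from compound 2 by 2-(methylcarbamoyl)pyridin-4-yl in place of 4-cyanophenyl on an oxygen on an aromatic ring. For the measured compounds named here, no measured pair frames this change, so the expected step from an at least 2.1-fold lower number from compound 2 to compound 3 (0.33 log units; beyond the scatter) is toward stronger inhibition, though its size is uncertain. Compound 3 is therefore estimated at 7000 nM in this assay, expected within 1500 nM to 20000 nM.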

Compound 3, half-maximal inhibitory concentration: > 15000 nM
Compound 3 gave a limit, no number; the forecaster's own chance of this, stated with the estimate: 35%; middle value at least 2.1-fold (0.33 log units) from the limit.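

No step can be read from compound 2 to compound 3, since both compounds stop at the same limit: the limit of > 15000 nM in this assay, at which 2 of the 3 values shown sit. As far as these compounds go, whether 2-(methylcarbamoyl)pyridin-4-yl in place of 4-cyanophenyl changes inhibition at all, and in which direction, stays open.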